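Working notes on cytotoxicity: compounds 1, 2 and 3

This account rests on a few compounds, and the source may have more. Where it says the series, first, only, none or still open, it means among the compounds named here.

Measured so far:
compound 1, `COC(=O)c1ccc(NCc2cncn2Cc2cccc([N+](=O)[O-])c2)cc1-c1ccccc1`: in a toxicity assay on NIH3T3 cells (Mus musculus) for cytotoxicity, read by resazurin assay (a lower number here means that less compound is needed, a higher number that more compound is needed for the effect), compound 1 gives > 10000 nM.
compound 2, `Fc1ccc(Cn2cncc2CNc2ccc(-c3nc4ccccc4s3)c(-c3ccccc3)c2)c(F)c1`: in this assay compound 2 gives > 1000 nM.

For compound 1 the value is a limit of the assay, not a number (the limit of > 10000 nM in this assay, at which 1 of the 2 values shown sits). For compound 2 the value is likewise a limit (the limit of > 1000 nM in this assay, at which 1 of the 2 values shown sits). Within the data shown here, both entries are limits, so no step between measured compounds can be read, and nothing is known about how the two compounds stand relative to each other within this assay.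

Compound 3, `COC(=O)c1ccc(NCc2cncn2Cc2ccccc2C#N)cc1-c1ccccc1`, is not yet measured in this assay. It differs from compound 1 by 2-cyanophenyl in place of 3-nitrophenyl on a saturated chain carbon bound to an aromatic nitrogen. With compound 1 giving only a limit, no shift beyond the scatter is expected in this assay, and the expected result for compound 3 is again a limit rather than a number. Compound 3 is expected at 15000 nM, with a range from 5000 nM to 50000 nM. This corresponds to an expected step that the limit leaves unreadable from compound 1 to compound 3.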

Compound 3, half-maximal effective concentration: 25000 nM
Compound 3: middle estimate off by 1.7-fold (0.22 log units), on the low side; the measured number falls inside the stated range.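

The value of compound 1 is a limit and not a number, so no step from compound 1 to compound 3 can be read: the limit of > 10000 nM in this assay, at which 1 of the 3 values shown sits.

The compounds shown leave open whether 2-cyanophenyl in place of 3-nitrophenyl shifts the value at all, and by how much.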